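From hydroxy to bromo: notes on compound 4

The compounds below may be only part of what the source reports. "The series", "measured", "known", "first", "only" and "open" are said of these compounds alone.

Measured in a functional assay on OVCAR-5 cells (Homo sapiens) for inhibition, read by CCK-8 assay, with a stated time of 72 h, tested at 1 uM; a higher number here means more inhibition of growth at the concentration tested, a lower number less inhibition of growth:
compound 1 `CN(C)C(=O)c1cc2cnc(Nc3ccc(N)cn3)nc2n1C1CCCC1`: 12.3%
compound 2 `CN(C)C(=O)c1cc2cnc(Nc3ccc(NC(=O)C4(C(=O)Nc5cccc(O)c5)CC4)cc3)nc2n1C1CCCC1`: 58.5%
compound 3 `CN(C)C(=O)c1cc2cnc(Nc3ccc(NC(=O)C4(C(=O)Nc5cccc(Cl)c5)CC4)cc3)nc2n1C1CCCC1`: 15.5%

Compound 2 stands highest of the three, with both gaps below it beyond the scatter. Compound 4 `CN(C)C(=O)c1cc2cnc(Nc3ccc(NC(=O)C4(C(=O)Nc5cccc(Br)c5)CC4)cc3)nc2n1C1CCCC1` differs from it in one place: bromo in place of hydroxy on an aromatic carbon. Going by the values given here, the one measured step bearing on this replaces the same hydroxy with chloro, a number 43 percentage points lower from compound 2 to compound 3 (beyond the scatter), a large drop beyond the scatter. Among the compounds with values here, no bromo compound has been measured, so the expectation rests on this single step. A large drop of similar size is expected in this assay. The expected step is a number 38.5 percentage points lower from compound 2 to compound 4 (beyond the scatter). For compound 4 the estimated value is 20%, with an expected range of 6% to 38%.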

Compound 4, percent growth inhibition at one concentration: 0.04%
The estimate for compound 4 lay 20 percentage points above the measured number; the measured number lies below the stated range.
By their numbers in this assay, from the lowest: compound 4; then compounds 1 and 3 (each within the scatter of the next); then compound 2.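

On the 3-hydroxyphenyl group, bromo in place of hydroxy leaves almost no growth inhibition in this assay and gives a number 58.5 percentage points lower from compound 2 to compound 4 (beyond the scatter) as its step. The two halogens are also not interchangeable here, as the change from chloro to bromo gives a number 15.5 percentage points lower from compound 3 to compound 4 (beyond the scatter) as a further step. Nothing measured on these compounds explains that difference.

On these data alone, whether an amine or a methoxy at this place would keep the inhibition seen with compound 2 stays open. So does whether fluoro would follow chloro and bromo.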